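A fluorophenyl amide replaces the tolyl amide

A few compounds are considered here, and "the series" means these few. Any claim that something is new, unique, unknown or untested is made for them only; others in the source may bear on it.

Measured so far in an assay on isolated protein for inhibition of Amine oxidase [flavin-containing] B (Homo sapiens), read by fluorescence and spectrophotometry; a lower number here means a stronger inhibitor, a higher number a weaker inhibitor:
compound 1, `O=C(CCc1cn(Cc2ccc3oc(-c4ccccc4)cc(=O)c3c2)nn1)Nc1ccccc1`, 15600 nM
compound 2, `Cc1ccc(NC(=O)CCCCc2cn(Cc3ccc4oc(-c5ccccc5)cc(=O)c4c3)nn2)cc1`, 15600 nM
compound 3, `O=C(CCc1cn(Cc2ccc3oc(-c4ccccc4)cc(=O)c3c2)nn1)Nc1ccc(F)cc1`, not yet measured

Compound 2 stands level with compound 1: in this assay compound 2 gives 15600 nM, and the step of no change at the digits printed from compound 1 to compound 2 (within the scatter) lies within the scatter, so the two compounds cannot be told apart on the numbers shown. That single step is the only measured one, and it is also the one that bears on the change now considered, since both alter the amide end that hangs off the shared core.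

Compound 3 differs from compound 2 in a group of 10 heavy atoms (7 carbon, 1 nitrogen, 1 oxygen, 1 fluorine; one six-membered aromatic ring of carbon only) in place of a group of 12 heavy atoms (10 carbon, 1 nitrogen, 1 oxygen; one six-membered aromatic ring of carbon only), on a saturated chain carbon, two bonds along the chain from an aromatic carbon. Within the scatter of the one measured step, the amide end has been altered with no visible effect on the reading of this assay, so the (4-fluorophenyl)carbamoyl group is expected to leave the reading where it is: the step of no change at the digits printed from compound 2 to compound 3 (within the scatter) is estimated to be no more than the scatter. Compound 3 is therefore expected to give about 15600 nM in this assay, in a range from 6000 nM to 40000 nM.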

Compound 3, half-maximal inhibitory concentration: 15600 nM
Beside the measured number, compound 3's estimate shows no gap at the digits printed; the measured number falls inside the stated range.
By their numbers in this assay, from the lowest: compounds 1, 2 and 3 (each within the scatter of the next).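

Among the compounds shown here, compound 3 gives the first reading for a single-atom change at this end of the molecule, fluoro in place of hydrogen on an aromatic carbon, and in this assay the result is no change at the digits printed from compound 1 to compound 3 (within the scatter) for that substitution. The other new comparison replaces the whole group on the saturated chain carbon, with (4-fluorophenyl)carbamoyl entering, and no change at the digits printed from compound 2 to compound 3 (within the scatter) is what it shows, so the three compounds now stand level across two kinds of change at the amide end, one confined to the aromatic ring and one involving the larger group. No measurement is available that would explain this lack of separation.

What the compounds shown leave open is whether this level holds for groups of another kind on the amide's aromatic ring, such as a methoxy, a trifluoromethyl or a nitrile, or for an amine or a carboxylic acid in place of the anilide. They also leave open whether any change at this end can move the reading at all, and whether a change to the shared core, such as a chlorine on its phenyl group, would do so instead.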